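Pyridin-4-yl in Place of 4-Fluorophenyl on the Amide Arm

A few compounds are considered here, and "the series" means these few. Any claim that something is new, unique, unknown or untested is made for them only; others in the source may bear on it.

Measured so far in a functional assay on A2780 cells (Homo sapiens) for cytotoxicity, read by MTT assay, with a stated time of 48 h; a higher number here means a weaker inhibitor, a lower number a stronger inhibitor:
compound 1 `CN(C)CCN1CCN(C2=Nc3ccccc3C(CC(=O)NCc3ccccc3)N2c2ccc(-c3ccccc3)cc2)CC1` gives 1390 nM
compound 2 `CN(C)CCN1CCN(C2=Nc3ccccc3C(CC(=O)NCc3ccc(F)cc3)N2c2ccc(-c3ccccc3)cc2)CC1` gives 1600 nM

Compound 2 holds the higher of the two numbers in this assay, though the gap to compound 1 is within the scatter. Going by the values given here, the only measured step is a 1.2-fold higher number from compound 1 to compound 2 (0.06 log units; within the scatter), and it corresponds to fluoro in place of hydrogen on an aromatic carbon. Compound 3 `CN(C)CCN1CCN(C2=Nc3ccccc3C(CC(=O)NCc3ccncc3)N2c2ccc(-c3ccccc3)cc2)CC1` differs from compound 2 by pyridin-4-yl in place of 4-fluorophenyl on a saturated chain carbon bound to an amide-type nitrogen. That measured step alters only a substituent on the aryl ring and stays within the scatter, so it says little about exchanging the whole ring for one with a hetero atom. Among the compounds with values here, no measured step bears directly on this change, and no step beyond the scatter is expected in this assay in either direction. Compound 3 is therefore estimated at 1600 nM, within 700 nM to 3600 nM, which amounts to an expected step of no change at the digits printed from compound 2 to compound 3 (within the scatter).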

Compound 3, half-maximal inhibitory concentration: > 5000 nM
Compound 3: no number, only a limit; the forecaster's own chance of this, stated with the estimate: 5%; middle value at least 3.1-fold (0.49 log units) away from the limit.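

In this assay compound 3 gives > 5000 nM, which is a limit of the assay and not a number: the limit of > 5000 nM in this assay, at which 1 of the 3 values shown sits.

Exchanging the whole ring on the amide arm does register in this series: pyridin-4-yl in place of 4-fluorophenyl gives an at least 3.1-fold higher number from compound 2 to compound 3 (0.49 log units; beyond the scatter), and pyridin-4-yl in place of phenyl gives an at least 3.5-fold higher number from compound 1 to compound 3 (0.55 log units; beyond the scatter). The arm is therefore not indifferent to every change, even though fluoro in place of hydrogen on its ring gave only a 1.2-fold higher number from compound 1 to compound 2 (0.06 log units; within the scatter).

How far compound 3 actually lies from the other two compounds cannot be read from a limit. The compounds shown also leave open whether the outcome depends on the ring nitrogen's location, as pyridin-3-yl or pyridin-2-yl would test, or holds for other rings such as pyrimidin-5-yl.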